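Pyridin-2-yl for pyridin-4-yl: expected edema inhibition of compound 4

The source may report more compounds than this note shows. Statements on the series, on what has been measured and on what is new or still open speak of the compounds shown alone.

Working notes on a three-compound set. Compound 1 `CN(C)c1ccc(C2CC(c3ccncc3)=NN2)cc1` gives in a functional assay on the whole organism (strain Charles Foster albino) for inhibition, with Rattus norvegicus as the target, read by paw edema, with stated times of 30 min and 3 h, at a dose of 50 mg/kg by the oral route (on this read-out lower numbers stand for less inhibition and higher numbers for more inhibition at the one dose given (going by the name of the read-out)), a reading of 0%. Compound 2 `COc1ccc(OC)c(C2CC(c3ccncc3)=NN2)c1` gives in this assay a reading of 13%, the second highest of the three numbers; compound 1 lies lower by a gap beyond the scatter, and compound 3 `COc1ccc(OC)c(-c2nc(-c3ccccn3)no2)c1`, which in this assay gives 28%, lies higher by a gap also beyond the scatter. For the measured compounds named here, compound 3 carries the pyridin-2-yl group on a different core from compound 2, so no single-place step joins the two; their values show only that a pyridin-2-yl compound reads above compound 2.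

Compound 4 `COc1ccc(OC)c(C2CC(c3ccccn3)=NN2)c1` is not yet measured. It differs from compound 2 by pyridin-2-yl in place of pyridin-4-yl on a carbon with a double bond to nitrogen. Going by the values given here, no step between measured compounds covers this change, so its size is open. The step is expected to be a modest rise, a number 7 percentage points higher from compound 2 to compound 4 (within the scatter), possibly still within the scatter. The expectation leans on compound 3, which with the same pyridin-2-yl group gives 28% in this assay. Compound 4 is therefore estimated at 20%, with a range from 5% to 38%.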

Compound 4, a percentage reported as inhibition, in the whole organism at one dose (the size of the read-out at that dose, not a potency): 15%
Beside the measured number, compound 4's estimate is 5 percentage points above it, and the stated range covers the measured number.
By their numbers in this assay, from the lowest: compound 1; then compounds 2 and 4 (each within the scatter of the next); then compound 3.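

In this assay, for the compounds shown here, the first direct reading of this exchange on the shared core is a number 2 percentage points higher from compound 2 to compound 4 (within the scatter), so pyridin-2-yl and pyridin-4-yl on this carbon with a double bond to nitrogen cannot be told apart at the one dose given. The pyridin-2-yl group alone therefore brings no gain beyond the scatter on this core, and nothing in this single step accounts for the reading of compound 3, whose core is different. Nothing measured here offers an explanation for the size of this step.

Going by these compounds, whether pyridin-3-yl, a plain phenyl ring or a carboxylic acid in the same place would shift the reading remains open. So does whether the same exchange gives a similar step on the core of compound 1, or at other doses.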